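The source may report more compounds than this note shows. Statements on the series, on what has been measured and on what is new or still open speak of the compounds shown alone.

Measured compounds:
- compound 1, `CC(C)Oc1cccc2ccc(N)nc12`, with 437 nM in an assay on cells with melanin-concentrating hormone receptor 1 (Homo sapiens) as the target, read by radioligand binding; a higher number here means a weaker inhibitor, a lower number a stronger inhibitor
- compound 2, `CCC(C)COc1cccc2ccc(N)nc12`, with 36 nM in this assay
- compound 3, `CCCOc1cccc2ccc(N)nc12`, with 1100 nM in this assay

Among these three values compound 1 stands second highest, nearest to compound 3 and furthest from compound 2. Compound 4, `CCC(CC)C(C)Oc1cccc2ccc(N)nc12`, has not yet been measured. It differs from compound 1 in one place: pentan-3-yl in place of methyl on a saturated chain carbon bound to an oxygen on an aromatic ring and a saturated chain carbon. The shared core and the oxygen on the aromatic ring are unchanged; only the alkyl group on that oxygen grows.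

Two of the measured steps bear on this change. Going from compound 1 to compound 2, where a larger branched alkyl replaces the isopropyl, the number fell sharply: a 12-fold lower number from compound 1 to compound 2 (1.08 log units; beyond the scatter). Going the other way, from compound 2 to compound 3, stripping the ethyl branch off the chain raised it even more: a 31-fold higher number from compound 2 to compound 3 (1.49 log units; beyond the scatter). The smaller step from compound 1 to compound 3 points the same way, with the unbranched propyl weaker: a 2.5-fold higher number from compound 1 to compound 3 (0.40 log units; beyond the scatter). Among the measured compounds shown here, compound 4 adds still more branched carbon to the chain, so a large fall in this assay is expected, though no measured compound reaches this size of group, so the extent is uncertain. For compound 4 the expected step is a 7.3-fold lower number from compound 1 to compound 4 (0.86 log units; beyond the scatter). The estimate for compound 4 is 60 nM, within a range of 15 nM to 250 nM.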

Compound 4, half-maximal inhibitory concentration: 191 nM
For compound 4 the middle estimate is 3.2-fold (0.50 log units) below the measured one; the measured number falls inside the stated range.
By their numbers in this assay, from the lowest: compound 2; then compound 4; then compound 1; then compound 3.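

In this assay, the change to compound 4 gave a 2.3-fold lower number from compound 1 to compound 4 (0.36 log units; beyond the scatter) and no more, so a group as large as this one still lowers the number relative to the isopropyl of compound 1, but only modestly. The earlier compounds had shown a much larger fall from the same starting point, a 12-fold lower number from compound 1 to compound 2 (1.08 log units; beyond the scatter) in that case, and on those compounds alone, more branched carbon on the oxygen could have seemed to bring a stronger inhibitor. Compound 4 goes against that reading: it carries the larger group, yet its fall from compound 1 is the smaller of the two, so among these compounds the amount of added carbon does not by itself set the number.

The compounds shown leave open whether the place of the branch along the chain matters as much as the size of the group, as compound 2 and compound 4 differ in both. They also leave open how a longer unbranched chain such as pentyl, or a cyclohexyl ring on the oxygen, would compare. No supporting data bear on why the fall for compound 4 is the smaller one.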